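Amino in Place of Methylsulfanyl: an Expected Gain

A few compounds are considered here, and "the series" means these few. Any claim that something is new, unique, unknown or untested is made for them only; others in the source may bear on it.

Compound 1 `CSc1nc(SC)c2ncn([C@@H]3C[C@@H](O)[C@H](CO)O3)c2n1` gives 225 uM in a functional assay on B-95-8 cells (Cercopithecidae) with B-95-8 cell line (Saguinus oedipus) as the target; a higher number here means a weaker inhibitor, a lower number a stronger inhibitor. Compound 2 `CN(C)c1nc(Br)nc2c1ncn2[C@@H]1C[C@@H](O)[C@H](CO)O1` reaches only the assay limit of > 300 uM in this assay. Compound 3 `Nc1nc(Br)nc2c1ncn2[C@@H]1C[C@@H](O)[C@H](CO)O1` gives 6 uM in this assay.

Of the two numbers measured, compound 1 holds the higher one, so it is the weaker inhibitor; compound 3 sits far below it. Compound 4 `CSc1nc(N)c2ncn([C@@H]3C[C@@H](O)[C@H](CO)O3)c2n1` differs from compound 1 in one place: amino in place of methylsulfanyl on an aromatic carbon. Among the compounds with values here, the one measured step of a related kind is an at least 50-fold lower number from compound 2 to compound 3 (1.69 log units; beyond the scatter), where an amino group likewise replaced a bulkier substituent, although that step starts from the limit of > 300 uM in this assay, at which 1 of the 3 values shown sits. A downward step of comparable direction is therefore expected, with a 15-fold lower number from compound 1 to compound 4 (1.18 log units; beyond the scatter). Compound 4 is estimated at 15 uM, ranging from 3 uM to 80 uM.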

Compound 4, concentration for 50% inhibition: > 300 uM
Compound 4: no number, only a limit (the forecaster's own chance of this, stated with the estimate: 5%); middle value at least 20-fold (1.30 log units) from the limit.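

Amino in place of methylsulfanyl brings no gain at this position in this assay, with an at least 1.3-fold higher number from compound 1 to compound 4 (0.12 log units; that floor lies within the scatter). The amino group alone therefore does not give activity on this core, and the group left at the other place counts heavily, as methylsulfanyl in place of bromo shows, with an at least 50-fold higher number from compound 3 to compound 4 (1.69 log units; beyond the scatter). The entry for compound 4 is a limit and not a number, so both steps are only floors: the limit of > 300 uM in this assay, at which 2 of the 4 values shown sit.

Still open, going by these compounds, is whether chloro or methoxy in place of the remaining methylsulfanyl of compound 4 would keep activity as bromo does in compound 3.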